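Shortening an Alkoxy Chain to a Methyl Group

The source may report more compounds than this note shows. Statements on the series, on what has been measured and on what is new or still open speak of the compounds shown alone.

Of the compounds shown here, two have been measured in a physicochemical assay for lipophilicity; a lower number here means a more polar compound, a higher number a more lipophilic compound. Compound 1 `Cc1ccc2[nH]c(-c3ccccc3)c(C3=C(Br)C(=O)NC3=O)c2c1` gives 2.88, while compound 2 `CCCCCCOc1ccc2[nH]c(-c3cccc(OC)c3)c(C3=C(Br)C(=O)NC3=O)c2c1` gives 3.92. Compound 2 therefore has the highest value of the two, sitting well above compound 1 by a gap that is beyond the usual scatter of this assay. Within the data shown here, the two compounds differ in more than one place, so no single step between them can be read off.

Compound 3 `COc1cccc(-c2[nH]c3ccc(C)cc3c2C2=C(Br)C(=O)NC2=O)c1` has not yet been measured. It differs from compound 2 in one place: methyl in place of hexyloxy on an aromatic carbon. A long chain carrying one oxygen is replaced by a single carbon, which is expected to push the value in this assay downward by a sizeable amount, well beyond the scatter. Compound 3 shares its methyl-bearing core with compound 1, whose value of 2.88 therefore serves as the main anchor. The step from compound 2 to compound 3 is estimated at a number 1.02 log units lower from compound 2 to compound 3 (beyond the scatter). For compound 3 the expected value in this assay is 2.9, with a likely range from 2.5 to 3.4.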

Compound 3, partition coefficient: 3.12
Compound 3: middle estimate off by 0.22 log units, on the low side; measured number inside the range.
By their numbers in this assay, from the lowest: compounds 1 and 3 (each within the scatter of the next); then compound 2.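

Among these compounds, for the first time, a single change at this aromatic carbon can be read in this assay on its own: methyl in place of hexyloxy gives a number 0.80 log units lower from compound 2 to compound 3 (beyond the scatter) and shows that this position responds clearly to the swap. Compound 1 and compound 2 differ in two places, and the other place can now be read as well: methoxy in place of hydrogen on an aromatic carbon gives a number 0.24 log units higher from compound 1 to compound 3 (within the scatter) and leaves compound 1 and compound 3 indistinguishable in this measurement. Nothing available here accounts for the size of either step.

With only hexyloxy and methyl shown at this position, it remains open how an intermediate group such as ethoxy or butoxy, or an amine or a carboxylic acid, would read in this assay there. From the compounds shown here alone, it also remains open whether the methoxy step would stay the same alongside hexyloxy, which would take a compound carrying hexyloxy with hydrogen in place of the methoxy.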